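The source may report more compounds than this note shows. Statements on the series, on what has been measured and on what is new or still open speak of the compounds shown alone.

Measured so far:
compound 1 `COc1cc(N(C)CCN(C)C)c(NC(=O)c2ccncc2OC)cc1Nc1nccc(-c2cn(C)c3ccccc23)n1`: 2690 nM
compound 2 `COc1cc(N(C)CCN(C)C)c(NC(=O)c2ccnc(Cl)c2)cc1Nc1nccc(-c2cn(CCCO)c3ccccc23)n1`: 2140 nM

In a functional assay on A549 cells (Homo sapiens) for antiproliferative activity, read by MTT assay, with a stated time of 72 h (a lower number here means a stronger inhibitor, a higher number a weaker inhibitor), compound 2 gives 2140 nM, the lowest of the two numbers in hand. The gap to compound 1 is within the usual scatter, so the two values cannot be placed in any order; both sit in the same range of modest activity.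

Compound 3 `COc1cc(N(C)CCN(C)C)c(NC(=O)c2ccncc2OC)cc1Nc1nccc(-c2cn(CCCO)c3ccccc23)n1` differs from compound 2 in one place: 3-methoxypyridin-4-yl in place of 2-chloropyridin-4-yl on a carbonyl carbon. Within the data shown here, no measured pair differs in exactly this place, so no measured step is available for it. What can be said is that compound 1 already carries the 3-methoxypyridin-4-yl carbonyl and in this assay compound 1 gives 2690 nM, a number indistinguishable from that of compound 2 within the scatter.

On that basis the expected step of a 1.2-fold higher number from compound 2 to compound 3 (0.07 log units; within the scatter) is none beyond the scatter, in either direction. Compound 3 is therefore expected at about 2500 nM, with a range from 1000 nM to 6500 nM reflecting the absence of a directly comparable pair.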

Compound 3, half-maximal inhibitory concentration: 2390 nM
Compound 3: the middle estimate sits 1.0-fold (0.02 log units) above what was measured, and the stated range covers the measured number.
By their numbers in this assay, from the lowest: compounds 2, 3 and 1 (each within the scatter of the next).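

In this assay, 3-methoxypyridin-4-yl in place of 2-chloropyridin-4-yl on the carbonyl carbon gives a 1.1-fold higher number from compound 2 to compound 3 (0.05 log units; within the scatter) with the rest of the molecule held constant, so this place accepts either group without a readable shift. The second place can now be read as well: 2-hydroxyethyl in place of hydrogen on a saturated chain carbon bound to an aromatic nitrogen gives a 1.1-fold lower number from compound 1 to compound 3 (0.05 log units; within the scatter) and likewise produces no readable shift, so neither change separates the three compounds in this set. No independent measurement bears on why these two changes leave the number within the scatter.

The compounds shown leave open whether any group at either place can move the number beyond the scatter, as both steps here stay inside it and each place is tested by a single change. A plain phenyl or a pyridine carrying an amine or a carboxylic acid on the carbonyl carbon, and a longer chain ending in an amine on the aromatic nitrogen, would probe each place further.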